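The compounds below may be only part of what the source reports. "The series", "measured", "known", "first", "only" and "open" are said of these compounds alone.

Of the compounds shown here, three have been measured in a functional assay on HepG2 cells (Homo sapiens) for antiproliferative activity, read by sulforhodamine B assay, with a stated time of 48 h; a higher number here means a weaker inhibitor, a lower number a stronger inhibitor. Compound 1 `Nc1ccc(S(=O)(=O)Nc2ccnc3cc(C(F)(F)F)ccc23)cc1` gives 93100 nM. Compound 2 `O=C(Nc1ccccc1)Nc1ccc(S(=O)(=O)Nc2ccnc3cc(C(F)(F)F)ccc23)cc1` is reported only as "not active" (no number reported), with no number given. Compound 3 `O=S(=O)(Nc1nccs1)c1ccc(N/C(S)=N\c2ccnc3cc(C(F)(F)F)ccc23)cc1` gives 28200 nM, the lower of the two reported numbers, and its gap to compound 1 lies beyond the usual scatter. Compound 4 `COc1cc(NS(=O)(=O)c2ccc(N/C(S)=N\c3ccnc4cc(C(F)(F)F)ccc34)cc2)nc(OC)n1` has not been measured yet. It differs from compound 3 by 2,6-dimethoxypyrimidin-4-yl in place of 1,3-thiazol-2-yl on a sulfonamide nitrogen. Going by the values given here, no measured pair shows the effect of such a swap, so in this assay only a small step is expected, a 1.1-fold lower number from compound 3 to compound 4 (0.05 log units; within the scatter), not beyond the scatter. Compound 4 is therefore estimated at 25000 nM, within 8000 nM to 80000 nM.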

Compound 4, half-maximal inhibitory concentration: 76700 nM
Estimate against measurement, compound 4: 3.1-fold (0.49 log units) below; low and high end bracket the measured number.
By their numbers in this assay, from the lowest: compound 3; then compounds 4 and 1 (each within the scatter of the next).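

Going by these compounds alone, compound 3 and compound 4 are the only pair here that differ in one place, and in this assay the swap of 1,3-thiazol-2-yl for 2,6-dimethoxypyrimidin-4-yl on a sulfonamide nitrogen gives a 2.7-fold higher number from compound 3 to compound 4 (0.43 log units; beyond the scatter), so the group held there can change the number beyond the scatter. Ring size and the methoxy groups change together in this swap, so this one pair cannot separate them. No measurement here explains the shift.

Still open, on these data alone, is how an unsubstituted pyrimidin-4-yl ring or a plain phenyl ring would read at this position. A methyl group there also remains untested among the compounds shown.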